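A few compounds are considered here, and "the series" means these few. Any claim that something is new, unique, unknown or untested is made for them only; others in the source may bear on it.

Working notes on the series.

Compound 1 `O=C(Nc1ccc(F)c(-c2nc3ncc(-c4ccc(F)cc4F)cc3[nH]2)c1)N1CCCC1` is the reference here. Among the compounds with values here, in an ADME assay on the whole organism (Mus musculus, strain Swiss Webster) for pharmacokinetics, read by LC-MS, at a dose of 50 mg/kg by the oral route (on this read-out higher numbers stand for higher exposure at the dose given and lower numbers for lower exposure), compound 1 gives 15600 ng.h/mL, the highest of the three numbers measured so far. Compound 2 `O=C(Nc1ccc(F)c(-c2nc3ncc(-c4cncc(F)c4)cc3[nH]2)c1)N1CCCC1` gives 1560 ng.h/mL, and compound 3 `O=C(Nc1ccc(F)c(-c2nc3ncc(-c4ccc(O)cc4)cc3[nH]2)c1)N1CCCC1` gives 137 ng.h/mL. Both changes at the same aromatic carbon lower exposure: a 10-fold lower number from compound 1 to compound 2 (1.00 log units; beyond the scatter), and a 110-fold lower number from compound 1 to compound 3 (2.06 log units; beyond the scatter); between the two replacements, an 11-fold lower number from compound 2 to compound 3 (1.06 log units; beyond the scatter).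

Compound 4 `O=C(Nc1ccc(F)c(-c2nc3ncc(-c4ccccc4F)cc3[nH]2)c1)N1CCCC1` is the next member. Against compound 1 the difference is hydrogen in place of fluoro on an aromatic carbon. The same difference, cut one bond further out, reads 2,4-difluorophenyl to 2-fluorophenyl; the fluoro that leaves sits para to a large group and meta to the remaining fluoro.

Within the data shown here, no measured step removes a single fluoro while keeping the ring of carbon only, so the bearing is indirect. The two measured replacements at this carbon both cost exposure, but each exchanges the whole 2,4-difluorophenyl, the smaller cost being that from compound 1 to compound 2. A change of one heavy atom is expected to cost less than either, most likely a modest lowering. The estimate for compound 4 in this assay is 7000 ng.h/mL, within 2500 ng.h/mL to 15000 ng.h/mL, i.e. an expected step of a 2.2-fold lower number from compound 1 to compound 4 (0.35 log units; beyond the scatter).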

Compound 4, area under the concentration-time curve: 4870 ng.h/mL
Compound 4: the middle estimate sits 1.4-fold (0.16 log units) above what was measured; the range from low to high includes it.
By their numbers in this assay, from the lowest: compound 3; then compound 2; then compound 4; then compound 1.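

In this assay, the loss of a single fluoro, para to a large group and meta to the remaining fluoro, is enough to move exposure beyond the scatter, with a 3.2-fold lower number from compound 1 to compound 4 (0.51 log units; beyond the scatter) on a ring that stays all carbon; until now, only exchanges of the whole 2,4-difluorophenyl had been seen at this carbon. The 2-fluorophenyl nevertheless keeps compound 4 clear of both earlier replacements, with a 3.1-fold higher number from compound 2 to compound 4 (0.49 log units; beyond the scatter) and, further, a 36-fold higher number from compound 3 to compound 4 (1.55 log units; beyond the scatter), so the position now shows graded exposure across four groups, with compound 1 on top and the single-fluoro loss taking up part of the drop seen in a 10-fold lower number from compound 1 to compound 2 (1.00 log units; beyond the scatter) without a change of ring atoms. Nothing measured here accounts for why exposure follows this fluoro.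

What the remaining fluoro contributes stays open, since the compounds shown hold no 4-fluorophenyl and no unsubstituted phenyl to set against compound 4. Also open, going by these compounds, is whether chloro, methoxy or an amine on the carbon that lost its fluoro would hold exposure nearer to compound 1 or fall towards compound 4.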